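The compounds below may be only part of what the source reports. "The series", "measured", "known", "first", "only" and "open" are said of these compounds alone.

Of the compounds shown here, three that share one core have been tested in an assay on HL-60 cells for inhibition of glutathione S-transferase P (Homo sapiens), read by spectrophotometry, tested at 20 uM; on this read-out lower numbers stand for less inhibition and higher numbers for more inhibition at the one concentration tested (going by the name of the read-out). Compound 1 `Cc1cccc2c1N(CC(=O)O)C/C(=C\c1cccc(O)c1)C2=O` gives 75.6%. Compound 2 `Cc1cccc(/C=C2\CN(CC(=O)O)c3c(C)cccc3C2=O)c1` gives 39.1%, and compound 3 `COc1ccc(/C=C2\CN(CC(=O)O)c3c(C)cccc3C2=O)cc1` gives 31.5%. Among these three numbers compound 2 stands second highest: its nearest neighbour is compound 3, and the step of a number 7.6 percentage points lower from compound 2 to compound 3 (within the scatter) lies within the scatter, so the two cannot be told apart; the furthest is compound 1, and the step of a number 36.5 percentage points lower from compound 1 to compound 2 (beyond the scatter) lies beyond the scatter.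

The new compound 4 `Cc1cccc(/C=C2\CN(CC(=O)O)c3c(Cl)cccc3C2=O)c1` is compound 2 with one change: chloro in place of methyl on an aromatic carbon. Going by the values given here, none of the measured steps touches this part of the core. The steps of a number 36.5 percentage points lower from compound 1 to compound 2 (beyond the scatter), a number 44.1 percentage points lower from compound 1 to compound 3 (beyond the scatter) and a number 7.6 percentage points lower from compound 2 to compound 3 (within the scatter) all swap the group on the double-bonded chain carbon while the core itself stays the same. So these data hold no example of trading methyl for chloro on the core, and no direction can be read from the measured steps. A step of no size beyond the scatter is therefore expected, a number 0.1 percentage points lower from compound 2 to compound 4 (within the scatter). Compound 4 is estimated at 39% in this assay, with a range from 20% to 58% that is kept wide to allow for the lack of a direct comparison.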

Compound 4, a percentage reported as inhibition, at one concentration (the size of the read-out at that concentration, not a potency): 45.6%
Compound 4: middle estimate off by 6.6 percentage points, on the low side; the range from low to high includes it.
By their numbers in this assay, from the lowest: compounds 3, 2 and 4 (each within the scatter of the next, the first and the last beyond it); then compound 1.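

In this assay, chloro in place of methyl on an aromatic carbon of the shared core gives a number 6.5 percentage points higher from compound 2 to compound 4 (within the scatter), so this read-out does not tell the two groups apart at this position. Going by these compounds alone, this is the first measured change on this part of the core, since every earlier step swapped the group on the double-bonded chain carbon, and it shows that a change here need not move the number beyond the scatter, at least when the 3-methylphenyl group is present. No measurement shown here offers an explanation for how closely compound 2 and compound 4 agree, and a single pair cannot establish a trend for this position.

Going by these compounds, it remains open whether a larger or chemically different group on the same aromatic carbon, such as bromo, a nitrile or an amine, would also leave the number within the scatter. On these data alone, it is equally open whether chloro in place of methyl would give a similar result alongside the 3-hydroxyphenyl group of compound 1 or the 4-methoxyphenyl group of compound 3.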